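This account rests on a few compounds, and the source may have more. Where it says the series, first, only, none or still open, it means among the compounds named here.

Compound 2 `Cn1c(CNc2ccccc2)cc2ccccc21` gives 75000 nM in an assay for inhibition of Amine oxidase [flavin-containing] B (Bos taurus), read by fluorescence (on this read-out lower numbers stand for stronger inhibition and higher numbers for weaker inhibition), the highest of the two numbers in hand. Among the compounds with values here, its only neighbour is compound 1 `c1ccc(NCc2cc3ccccc3[nH]2)cc1`, which gives 320 nM in this assay; the step of a 230-fold higher number from compound 1 to compound 2 (2.37 log units; beyond the scatter) separates the two.

Compound 3 `CN(Cc1cc2ccccc2n1C)c1ccccc1` differs from compound 2 by methyl in place of hydrogen on a nitrogen on an aromatic ring. Within the data shown here, the one measured step that bears on adding a methyl to a nitrogen is the step from compound 1 to compound 2, and it moved the number far upward. Among the measured compounds shown here, that step concerns a different nitrogen, so it is a loose guide only; no measured pair speaks directly to methylation of the nitrogen changed here. On that basis a further rise in this assay, smaller than the earlier one and not certainly beyond the scatter, is expected for compound 3, i.e. an expected step of a 2.0-fold higher number from compound 2 to compound 3 (0.30 log units; within the scatter). For compound 3 the estimated value in this assay is 150000 nM, with a range from 40000 nM to 600000 nM.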

Compound 3, inhibition constant: 11000 nM
Compound 3: middle estimate off by 14-fold (1.13 log units), on the high side, outside the stated range (below it).
By their numbers in this assay, from the lowest: compound 1; then compound 3; then compound 2.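

Methyl in place of hydrogen on a nitrogen on an aromatic ring, whose other neighbours are an aromatic carbon and a saturated chain carbon, gives a 6.8-fold lower number from compound 2 to compound 3 (0.83 log units; beyond the scatter) in this assay and so runs opposite in direction to a 230-fold higher number from compound 1 to compound 2 (2.37 log units; beyond the scatter) at the other nitrogen. The same exchange therefore does not act alike at the two nitrogens, and at this position the methyl recovers only a modest part of the large earlier rise. Nothing available explains this difference between the two nitrogens.

Open, from the compounds shown here alone, is whether the methyl at this position lowers the number by a similar step when the other nitrogen carries hydrogen. Also open, going by these compounds, is how a longer chain such as ethyl, or an acetyl group, on this nitrogen would compare with methyl.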